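The source may report more compounds than this note shows. Statements on the series, on what has been measured and on what is new or still open speak of the compounds shown alone.

Measured compounds:
compound 1, `COc1ccc(-c2csc(=O)n2-c2cc(OC)c(OC)c(OC)c2)cc1`: 1800 nM
compound 2, `COc1ccc(-c2c(Cl)sc(=O)n2-c2cc(OC)c(OC)c(OC)c2)cc1`: > 20000 nM (a limit of the assay)

For the measured compounds named here, in a functional assay on CCRF-CEM cells (Homo sapiens) for antiproliferative activity, with a stated time of 72 h (a lower number here means a stronger inhibitor, a higher number a weaker inhibitor), compound 1 gives 1800 nM, and this is the only actual number among the two measured compounds. For compound 2 the assay reports only a limit, > 20000 nM. Going by the values given here, the single measured step, an at least 11-fold higher number from compound 1 to compound 2 (1.04 log units; beyond the scatter), is therefore known only as a lower bound on its size, as the limit of > 20000 nM in this assay, at which 1 of the 2 values shown sits, shows.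

Compound 3, `COc1ccc(-c2csc(=O)n2-c2cc(OC)c(OC)c(OC)c2)cc1[N+](=O)[O-]`, is not yet measured. It differs from compound 1 in one place: nitro in place of hydrogen on an aromatic carbon. Among the compounds with values here, the one measured step, an at least 11-fold higher number from compound 1 to compound 2 (1.04 log units; beyond the scatter), concerns a different group entering at a different aromatic carbon of the shared core, so it bears on the change to compound 3 only loosely, as a sign that a substituent placed on an aromatic carbon of this core gave a weaker inhibitor. On that basis a step toward a higher number in this assay is expected for compound 3, of moderate size rather than the large one seen with compound 2: a 2.5-fold higher number from compound 1 to compound 3 (0.40 log units; beyond the scatter). Compound 3 is accordingly estimated at 4500 nM, with a range from 1200 nM to 16000 nM.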

Compound 3, half-maximal inhibitory concentration: 8200 nM
Beside the measured number, compound 3's estimate is 1.8-fold (0.26 log units) below it, and the stated range covers the measured number.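

In this assay, nitro on the six-membered aromatic ring of carbon only, ortho to a methoxy group and meta to a large group, gives a 4.6-fold higher number from compound 1 to compound 3 (0.66 log units; beyond the scatter). This adds a second place on the shared core, apart from the carbon that takes chloro in compound 2, where a substituent goes with a weaker inhibitor, and here the change has a measured size: compound 3 still gives an actual number, 8200 nM. The step to compound 2 remains only a bound, so the two changes from compound 1 agree in direction but their sizes cannot be set exactly against each other: the limit of > 20000 nM in this assay, at which 1 of the 3 values shown sits.

The compounds shown leave open whether an amine, a hydroxyl group or a single fluorine on this same carbon would move the number as nitro does, or whether the loss belongs to nitro alone. They also leave open what underlies the step, as nothing shown measures any property of nitro at this place.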